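The compounds below may be only part of what the source reports. "The series", "measured", "known", "first", "only" and "open" are said of these compounds alone.

Compound 1 `Cc1ccc(-c2cc(N)n(-c3cccc(Cl)c3)n2)cc1` gives 56600 nM in a functional assay on Jurkat cells (Homo sapiens) for inhibition, read by MTT assay, with a stated time of 72 h; on this read-out higher numbers stand for weaker inhibition of growth and lower numbers for stronger inhibition of growth. For compound 2 `Nc1cc(-c2ccc(Cl)cc2)nn1-c1cccc(Cl)c1` the result is a limit of the assay, > 100000 nM. Compound 3 `Cc1ccc(-c2cc(N)n(-c3ccc(Br)cc3)n2)cc1` gives 45000 nM.

Among the measured compounds shown here, the one measured pair that differs in a single place is compound 1 and compound 2: chloro in place of methyl on an aromatic carbon. The step was an at least 1.7-fold higher number from compound 1 to compound 2 (0.24 log units; that floor lies within the scatter), and its size is capped by the limit of > 100000 nM in this assay, at which 1 of the 3 values shown sits. Compound 4 `Nc1cc(-c2ccc(Cl)cc2)nn1-c1ccc(Br)cc1` has not been measured. It stands to compound 3 as compound 2 stands to compound 1: chloro in place of methyl on an aromatic carbon. The two places read the same, so this is the same change. The difference between the cores of compound 3 and compound 1 is not broken down here.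

Resting on the step of an at least 1.7-fold higher number from compound 1 to compound 2 (0.24 log units; that floor lies within the scatter), compound 4 is expected to move by a 2.0-fold higher number from compound 3 to compound 4 (0.30 log units; within the scatter). Compound 4 is therefore estimated at 90000 nM, between 40000 nM and 200000 nM.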

Compound 4, concentration for 50% growth inhibition: 61300 nM
Beside the measured number, compound 4's estimate is 1.5-fold (0.17 log units) above it; low and high end bracket the measured number.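

Chloro in place of methyl gives a 1.4-fold higher number from compound 3 to compound 4 (0.13 log units; within the scatter). Seen on two cores, this change produces no step that stands clear of the scatter, so no firm shift is shown on either core: the same change on two cores in this assay, an at least 1.7-fold higher number (0.24 log units; that floor lies within the scatter) from compound 1 to compound 2 and a 1.4-fold higher number (0.13 log units; within the scatter) from compound 3 to compound 4; the limit leaves it open whether they differ. Compound 2 sits at a limit of the assay, so it is not shown that the change carries the same size from one core to the other: the limit of > 100000 nM in this assay, at which 1 of the 4 values shown sits.

The compounds shown leave open what an amine, a carboxylic acid or a longer chain would do in place of the methyl or chloro. Among the compounds shown here, with only two cores carrying this change, its behaviour on further cores also remains open.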